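Trifluoromethyl hydroxy amides at the potassium channel: a sulfonamide swap

A few compounds are considered here, and "the series" means these few. Any claim that something is new, unique, unknown or untested is made for them only; others in the source may bear on it.

Compound 1 `Cn1nnnc1-c1ccc(NC(=O)C(C)(O)C(F)(F)F)cc1` — in an assay on a protein complex (Cavia porcellus) with sulfonylurea receptors; K-ATP channels (Homo sapiens) as the target (a higher number here means a weaker inhibitor, a lower number a stronger inhibitor), compound 1 gives 30900 nM.
Compound 2 `CC(O)(C(=O)Nc1ccc(S(=O)(=O)N2CCNCC2)cc1)C(F)(F)F` — in this assay compound 2 gives > 30000 nM.

Two compounds share the hydroxy trifluoromethyl propanamide attached to an aniline; they differ in what the aromatic ring carries. Compound 1 sits near the top of the range covered in this assay. For compound 2 the reading is a limit of the assay and not a number, namely (the limit of > 30000 nM in this assay, at which 1 of the 2 values shown sits). Compound 2 therefore stands at or beyond the weak end of what this series shows, and whether it is weaker than compound 1 cannot be told from these two values.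

Compound 3 `CCN(CC)S(=O)(=O)c1ccc(NC(=O)C(C)(O)C(F)(F)F)cc1` is the next member to be measured. It changes the sulfonyl substituent: diethylamino in place of piperazin-1-yl on a sulfonyl sulfur. Within the data shown here, no step between measured compounds in this assay is available to gauge what this exchange does. Compound 3 is therefore expected to stay close to the limit of this assay, with the estimated step of a number no higher from compound 2 to compound 3 (the limit leaves the size open) lying within the scatter of repeated measurements. For compound 3 the expected value in this assay is 30000 nM, within a range of 8000 nM to 100000 nM.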

Compound 3, half-maximal inhibitory concentration: 810 nM
For compound 3 the middle estimate is 37-fold (1.57 log units) above the measured one, outside the stated range (below it).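

In this assay, the sulfonyl sulfur proves to be a place where the substituent matters: diethylamino in place of piperazin-1-yl brings an at least 37-fold lower number from compound 2 to compound 3 (1.56 log units; beyond the scatter), so the presence of a sulfonyl group alone does not set the reading. The aromatic carbon that carries the whole substituent also responds, as diethylsulfamoyl in place of 1-methyl-1H-tetrazol-5-yl brings a 38-fold lower number from compound 1 to compound 3 (1.58 log units; beyond the scatter), which places compound 3 clear of both other compounds. The reading of compound 2 is a limit of the assay and not a number: the limit of > 30000 nM in this assay, at which 1 of the 3 values shown sits.

As far as these compounds go, whether the change at the sulfonyl sulfur follows from the two ethyl chains, the loss of the six-membered ring or the loss of the hydrogen-bond donor stays open, as all of these change together in this one exchange. Dimethylamino, piperidin-1-yl or morpholin-4-yl on the same sulfonyl sulfur would begin to separate these, and dipropylamino would show whether a longer chain carries the value further in the same direction.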